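Phenyl in Place of Cyclohexylmethyl on the Sulfur

A few compounds are considered here, and "the series" means these few. Any claim that something is new, unique, unknown or untested is made for them only; others in the source may bear on it.

Compounds measured so far:
compound 1, `OC[C@H]1O[C@@H](n2cnc3c(NCc4ccco4)ncnc32)[C@H](O)[C@@H]1O`: 36300 nM
compound 2, `OC[C@H]1O[C@@H](n2cnc3c(OCc4ccccc4)ncnc32)[C@H](O)[C@@H]1O`: 2090 nM
compound 3, `OC[C@H]1O[C@@H](n2cnc3c(SCC4CCCCC4)ncnc32)[C@H](O)[C@@H]1O`: 1550 nM

These numbers come from an assay on isolated protein for binding affinity to Equilibrative nucleoside transporter 1 (Homo sapiens); on this read-out higher numbers stand for weaker inhibition and lower numbers for stronger inhibition. Going by the values given here, compound 3 shows the lowest number of the three, but compound 2 sits within the scatter of it; only the steps from compound 1 are large: a 23-fold lower number from compound 1 to compound 3 (1.37 log units; beyond the scatter) and a 17-fold lower number from compound 1 to compound 2 (1.24 log units; beyond the scatter). Compound 4, `OC[C@H]1O[C@@H](n2cnc3c(Sc4ccccc4)ncnc32)[C@H](O)[C@@H]1O`, differs from compound 3 in one place: phenyl in place of cyclohexylmethyl on a sulfur. Among the compounds with values here, the one measured step at this part of the molecule, a 1.3-fold lower number from compound 2 to compound 3 (0.13 log units; within the scatter), stayed within the scatter, and both large steps concern the amino group of compound 1 rather than what hangs beyond the sulfur. A change here is therefore expected to give little: a 1.2-fold higher number from compound 3 to compound 4 (0.06 log units; within the scatter). Compound 4 is estimated at 1800 nM, with a range from 500 nM to 6500 nM.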

Compound 4, half-maximal inhibitory concentration: 91200 nM
Beside the measured number, compound 4's estimate is 51-fold (1.70 log units) below it; measured number outside the range, above it.
By their numbers in this assay, from the lowest: compounds 3 and 2 (each within the scatter of the next); then compound 1; then compound 4.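

What sits on the sulfur clearly matters: phenyl costs far more than cyclohexylmethyl (a 59-fold higher number from compound 3 to compound 4 (1.77 log units; beyond the scatter)), and phenylsulfanyl also falls well behind benzyloxy (a 44-fold higher number from compound 2 to compound 4 (1.64 log units; beyond the scatter)). Even the ((furan-2-yl)methyl)amino group of compound 1 does better (a 2.5-fold higher number from compound 1 to compound 4 (0.40 log units; beyond the scatter)), so the large gains over that group do not extend to phenylsulfanyl. Nothing available here explains this loss.

Going by these compounds, the change replaces a non-aromatic ring with an aromatic one and removes the methyl link in a single step, so their separate contributions stay unknown. Benzylsulfanyl and cyclohexylsulfanyl could pull them apart, and what they would give remains open.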